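Chain Extension on Two Cores Against Inducible Nitric Oxide Synthase

The source may report more compounds than this note shows. Statements on the series, on what has been measured and on what is new or still open speak of the compounds shown alone.

Compound 1 `CCCC(=O)NCCC(=O)c1cc(OC)ccc1N` and compound 2 `CCCCC(=O)NCCC(=O)c1cc(OC)ccc1N` share one core. In an assay for inhibition of Nitric oxide synthase, inducible (Homo sapiens), read by scintillation counting, with a stated time of 30 min, tested at 1 mM (on this read-out higher numbers stand for more inhibition at the one concentration tested (going by the name of the read-out) and lower numbers for less inhibition), compound 1 gives 7.35%, and compound 2 gives 14.1%. The change between them, (methyl in place of hydrogen on a saturated chain carbon, three bonds along the chain from a carbonyl carbon), made the step of a number 6.8 percentage points higher from compound 1 to compound 2 (within the scatter). Compound 3 `CCNC(=O)NCCC(O)c1cc(OC)ccc1N` rests on another core; the difference between the two cores is not broken down here. In this assay compound 3 gives 26.6%, the highest of the three. Compound 4 `CCCNC(=O)NCCC(O)c1cc(OC)ccc1N` is not yet measured and differs from compound 3 by methyl in place of hydrogen on a saturated chain carbon, two bonds along the chain from an amide-type nitrogen. Going by the values given here, this is the same kind of change as the one from compound 1 to compound 2, though the place differs: there it sits three bonds along the chain from a carbonyl carbon, here two bonds along the chain from an amide-type nitrogen. Because the step of a number 6.8 percentage points higher from compound 1 to compound 2 (within the scatter) stayed within the scatter, compound 4 is expected to give about 30%, between 18% and 42%. The expected step is a number 3.4 percentage points higher from compound 3 to compound 4 (within the scatter).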

Compound 4, a percentage reported as inhibition, at one concentration (the size of the read-out at that concentration, not a potency): 14.7%
Compound 4: the middle estimate sits 15.3 percentage points above what was measured; measured number outside the range, below it.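

On the core of compound 3, the added methyl gave a number 11.9 percentage points lower from compound 3 to compound 4 (beyond the scatter) in this assay. The same kind of change therefore did not carry over from one core to the other with the same direction or size: the same change on two cores in this assay, a number 6.8 percentage points higher (within the scatter) from compound 1 to compound 2 and a number 11.9 percentage points lower (beyond the scatter) from compound 3 to compound 4, 18.7 percentage points apart, beyond the scatter of two such steps

This does not show why the steps part ways, since the core and the place of the methyl differ together, with the methyl three bonds along the chain from a carbonyl carbon in one pair and two bonds along the chain from an amide-type nitrogen in the other. The compounds shown leave open how a longer chain, such as butylamino in place of propylamino, would read on the core of compound 3. They also leave open whether a carboxylic acid at the chain end would read differently on the two cores.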